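Series notes: cyano in place of carbamoyl

The source may report more compounds than this note shows. Statements on the series, on what has been measured and on what is new or still open speak of the compounds shown alone.

compound 1 `CCc1nc(-c2ccc(OC)cc2)c(C(=O)N2CCN(c3cccc(Cl)c3)CC2)o1`: > 1000 nM
compound 2 `Cc1nc(-c2ccccc2)c(C(=O)N2CCN(c3cccc(C(N)=O)c3)CC2)o1`: 71 nM
compound 3 `COc1cc(OC)cc(N2CCN(C(=O)c3oc(C)nc3-c3cccc(F)c3)CC2)c1`: 28.2 nM

In a functional assay on HL-60 cells (Homo sapiens) for inhibition, read by MTT assay, with a stated time of 72 h (on this read-out lower numbers stand for stronger inhibition and higher numbers for weaker inhibition), compound 1 gives > 1000 nM, which is a limit of the assay rather than a number. Compound 2 gives 71 nM and compound 3 gives 28.2 nM. Of the two numbers, compound 2 stands highest; compound 3 is the nearer, with a gap beyond the scatter. Compound 4 `Cc1nc(-c2ccccc2)c(C(=O)N2CCN(c3cccc(C#N)c3)CC2)o1` differs from compound 2 by cyano in place of carbamoyl on an aromatic carbon. Going by the values given here, no measured pair shows this change, so its size in this assay is open; a step within the usual scatter, in either direction, is expected. Compound 4 is therefore estimated at 90 nM, with a range of 30 nM to 300 nM. That expectation corresponds to a 1.3-fold higher number from compound 2 to compound 4 (0.10 log units; within the scatter).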

Compound 4, half-maximal inhibitory concentration: 39.6 nM
Estimate against measurement, compound 4: 2.3-fold (0.36 log units) above; the range from low to high includes it.
By their numbers in this assay, from the lowest: compounds 3, 4 and 2 (each within the scatter of the next, the first and the last beyond it). At a limit, above all of these: compound 1.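

In this assay, carbamoyl on the aromatic carbon can give way to cyano without a loss beyond the scatter, a 1.8-fold lower number from compound 2 to compound 4 (0.25 log units; within the scatter). The hydrogen-bond donor of carbamoyl, absent from cyano, is therefore not needed at this position for a value in this range. The step is read between two numbers, clear of the limit of the assay: the limit of > 1000 nM in this assay, at which 1 of the 4 values shown sits.

The compounds shown leave open how a carboxylic acid or an aminomethyl group would read at this position. From the compounds shown here alone, whether the same change holds with other groups on the shared core is also open.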